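Azido for methoxy on an inactive compound

The source may hold more compounds than are shown below. What is called first, only, known or untested is meant among the compounds shown, and "the series" means these compounds.

Compound 1 `COc1ccc(CN(C(=O)CSC(=S)N2CCc3cc(Br)ccc32)c2cc(OC)c(OC)c(OC)c2)cc1`: > 20000 nM
Compound 2 `COc1ccc(CN(C(=O)CSC(=S)N2CCCc3cc(OC)ccc32)c2cc(OC)c(OC)c(OC)c2)cc1`: 8210 nM
Compound 3 `COc1ccc(CN(C(=O)CSC(=S)N2CCN(C(=O)OC(C)(C)C)CC2)c2cc(OC)c(OC)c(OC)c2)cc1OC`: > 20000 nM

In a functional assay on MGC-803 cells (Homo sapiens) for inhibition, read by CCK-8 assay, with a stated time of 48 h (on this read-out higher numbers stand for weaker inhibition and lower numbers for stronger inhibition), compound 3 gives > 20000 nM, which is a limit and not a number. The set offers little to lean on, with the limit of > 20000 nM in this assay, at which 2 of the 3 values shown sit. Compound 4 `COc1ccc(CN(C(=O)CSC(=S)N2CCN(C(=O)OC(C)(C)C)CC2)c2cc(OC)c(OC)c(OC)c2)cc1N=[N+]=[N-]` differs from compound 3 in one place: azido in place of methoxy on an aromatic carbon. This puts azido in place of methoxy on an aromatic carbon, ortho to a methoxy group. Within the data shown here, the only measured step, an at least 2.4-fold lower number from compound 1 to compound 2 (0.38 log units; beyond the scatter), concerns the group on a thiocarbonyl carbon, so it bears only loosely on this change. No firm direction is therefore expected, and any expected shift is small. The estimated step is an at least 1.1-fold lower number from compound 3 to compound 4 (0.04 log units; that floor lies within the scatter). Compound 4 is expected at 18000 nM, within an estimated range of 5000 nM to 40000 nM.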

Compound 4, half-maximal inhibitory concentration: 810 nM
For compound 4 the middle estimate is 22-fold (1.35 log units) above the measured one, outside the stated range (below it).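

In this assay, azido in place of methoxy, ortho to a methoxy group, gives an at least 24-fold lower number from compound 3 to compound 4 (1.39 log units; beyond the scatter). The earlier step concerned only the group on the thiocarbonyl carbon; this one shows that a single change on the aromatic ring can also move a compound strongly on this read-out. The true size of the step stays unknown, since compound 3 stands at a limit and not at a number: the limit of > 20000 nM in this assay, at which 2 of the 4 values shown sit.

Going by these compounds, whether azido itself is special remains open, since an amine, a nitro group or a bromine at this place would test that. Also open, on these data alone, is whether azido gives the same gain with other groups on the thiocarbonyl carbon.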